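The source may report more compounds than this note shows. Statements on the series, on what has been measured and on what is new or still open speak of the compounds shown alone.

Compound 3 `CC(C)(CC(=O)Nc1cccc(OCc2ccc3ccc(F)cc3n2)c1)C(=O)O` is one of three compounds examined in a functional assay on ileum (Cavia porcellus) for antagonist activity at cysteinyl leukotriene receptor (Homo sapiens) (a higher number here means a weaker inhibitor, a lower number a stronger inhibitor), where compound 3 gives 1.4 nM. Compound 2 `CCC(CC)(CC(=O)Nc1cccc(OCc2ccc3ccccc3n2)c1)C(=O)O` gives 0.9 nM, and the gap between compound 2 and compound 3 lies within the scatter of the assay. Compound 1 `CCC(CC)(CC(=O)Nc1cccc(OCc2ccc3ccc(Br)cc3n2)c1)C(=O)O` gives 4 nM, a number beyond the scatter above that of compound 3. Within the data shown here, the single step measured in one place is a 4.4-fold lower number from compound 1 to compound 2 (0.65 log units; beyond the scatter), a hydrogen in place of bromo on an aromatic carbon.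

Compound 4 `O=C(CC1(C(=O)O)CCCC1)Nc1cccc(OCc2ccc3ccc(F)cc3n2)c1` differs from compound 3 by 1-carboxycyclopentyl in place of 1-carboxy-1-methylethyl on a saturated chain carbon bound to a carbonyl carbon. Among the measured compounds shown here, no measured step touches this part of the molecule: compound 2 and compound 3 differ in two places at once, so their values show only that they sit within scatter of one another, and the step from compound 1 to compound 2 concerns the aromatic substituent alone. With nothing in the record pointing either way, the change is expected to give a 1.2-fold lower number from compound 3 to compound 4 (0.07 log units; within the scatter), a step that stays within the scatter. Compound 4 is therefore estimated at 1.2 nM, with a range of 0.4 nM to 4 nM.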

Compound 4, half-maximal inhibitory concentration: 10 nM
Estimate against measurement, compound 4: 8.3-fold (0.92 log units) below, and the stated range ends below it.
By their numbers in this assay, from the lowest: compounds 2 and 3 (each within the scatter of the next); then compound 1; then compound 4.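

Among these compounds, the step is the first measured at this position, and in this assay it reads a 7.1-fold higher number from compound 3 to compound 4 (0.85 log units; beyond the scatter): on a saturated chain carbon bound to a carbonyl carbon, 1-carboxycyclopentyl gives a weaker inhibitor than 1-carboxy-1-methylethyl. The position is therefore not indifferent to this change, which takes the group from 6 to 8 heavy atoms and adds a five-membered non-aromatic ring of carbon only. Nothing available explains the drop in strength.

As far as these compounds go, whether the ring itself or the added carbon count matters remains open, and compounds 1 and 2 cannot settle it, since each differs from compound 3 and compound 4 in more than one place. Also open, from the compounds shown here alone, is how a cyclopropane ring, a cyclohexane ring or an open 1-carboxy-1-ethylpropyl group would fare on the core of compound 3.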